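The source may report more compounds than this note shows. Statements on the series, on what has been measured and on what is new or still open speak of the compounds shown alone.

Measured so far in a physicochemical assay, read by spectrophotometry, with a stated time of 30 min; a higher number here means a weaker inhibitor, a lower number a stronger inhibitor:

Compound 1 `Cc1ccc(OCc2cn(Cc3cccc(Cl)c3)nn2)cc1` gives 16.3 ug/mL.
Compound 2 `Cc1ccc(OCc2cn(Cc3ccc(Br)cc3)nn2)cc1` gives 16.3 ug/mL.
Compound 3 `Clc1cccc(Cn2cc(COc3c(Cl)cc(Cl)cc3Cl)nn2)c1` gives 16.4 ug/mL.

The three values sit on top of one another; in this assay no one of them can be set apart from the others.

Compound 1 and compound 2 differ in one place: 4-bromophenyl in place of 3-chlorophenyl on a saturated chain carbon bound to an aromatic nitrogen. The step this made was no change at the digits printed from compound 1 to compound 2 (within the scatter). The change thus left the read-out where it was.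

Compound 3 carries a different core from compound 1. The values of compound 1 and compound 3 are within the scatter of each other; the difference between the two cores is not broken down here.

Compound 4 `Clc1cc(Cl)c(OCc2cn(Cc3ccc(Br)cc3)nn2)c(Cl)c1` is not yet measured. It stands to compound 3 as compound 2 stands to compound 1: 4-bromophenyl in place of 3-chlorophenyl on a saturated chain carbon bound to an aromatic nitrogen. The place of the change is described in the same words for both pairs, so this is the same change, made a second time, now on the core of compound 3.

For the measured compounds named here, the only guide to its effect is the single earlier instance. On that basis the step from compound 3 to compound 4 is expected to be a 1.0-fold lower number from compound 3 to compound 4 (0.00 log units; within the scatter), which rests on no change at the digits printed from compound 1 to compound 2 (within the scatter) and on the fact that the three measured values do not separate. Compound 4 is accordingly estimated at 16.3 ug/mL in this assay. The range of the estimate for compound 4 is expected to run from 9.5 ug/mL to 28 ug/mL, wider than the scatter alone, since the change has been seen only once and on one core.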

Compound 4, half-maximal inhibitory concentration: 14 ug/mL
Estimate against measurement, compound 4: 1.2-fold (0.07 log units) above; the range from low to high includes it.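

In this assay, for the compounds shown here, the change to 4-bromophenyl in place of 3-chlorophenyl, on a saturated chain carbon bound to an aromatic nitrogen, gives a 1.2-fold lower number from compound 3 to compound 4 (0.07 log units; within the scatter) and, on the core of compound 1, gives no change at the digits printed from compound 1 to compound 2 (within the scatter) as its one earlier instance. The change therefore carries from one core to the other with neither step leaving the scatter, but two steps of this kind show only that the read-out tolerates this swap on these two cores, not that a change with a real effect would carry across cores in the same way, and not what the halogen and its place each contribute, since the two alter together. Nothing available bears on why the read-out holds steady across this change.

All the compounds shown keep a halogen-bearing phenyl on the chain carbon bound to the aromatic nitrogen, so it remains open whether an amine, a carboxylic acid or a longer chain at that place would shift the read-out in this assay at all. On these data alone, it also remains open whether the same swap stays this quiet on a core carrying a nitrile or a methoxy group in place of the methyl or chlorine substituents seen here.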